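Swapping methoxy for fluoro on a stilbene-type core

The source may hold more compounds than are shown below. What is called first, only, known or untested is meant among the compounds shown, and "the series" means these compounds.

Measured compounds:
compound 1 `Fc1cccc(/C=C/c2ccccc2)c1` gives 3100 nM
compound 2 `Cc1ccc(/C=C/c2cccc(F)c2)cc1` gives 800 nM
compound 3 `COc1ccc(/C=C/c2cc(F)ccc2F)cc1` gives 3200 nM

All three were tested in an assay on HepG2 cells for activation of nuclear factor erythroid 2-related factor 2 (Homo sapiens), read by a luciferase reporter, with a stated time of 5 h; a lower number here means that less compound is needed, a higher number that more compound is needed for the effect. Compound 3 has the highest number of the three; its value and that of compound 1 are within the scatter of each other, while compound 2 lies beyond the scatter below both. Among the compounds with values here, the only single-point step measured is a 3.9-fold lower number from compound 1 to compound 2 (0.59 log units; beyond the scatter), a modest change.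

Compound 4 `Fc1ccc(/C=C/c2cc(F)ccc2F)cc1` differs from compound 3 by fluoro in place of methoxy on an aromatic carbon, placed on an aromatic carbon of a six-membered aromatic ring of carbon only, para to a large group. Within the data shown here, no measured step replaces a methoxy with a fluoro, so the methyl step gives no direct guide. Compound 4 is therefore expected near compound 3, with a step of a 1.1-fold lower number from compound 3 to compound 4 (0.03 log units; within the scatter) that stays within the scatter, and an estimated value of 3000 nM (range 1200 nM to 7500 nM).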

Compound 4, half-maximal effective concentration: 2900 nM
Compound 4: middle estimate off by 1.0-fold (0.01 log units), on the high side, within the range that was stated.
By their numbers in this assay, from the lowest: compound 2; then compounds 4, 1 and 3 (each within the scatter of the next).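

Fluoro in place of methoxy on this aromatic carbon, para to a large group, gives a 1.1-fold lower number from compound 3 to compound 4 (0.04 log units; within the scatter), the first measured change at this position on the doubly fluorinated core. The swap removes the hydrogen-bond acceptor of the methoxy, yet the number stays within the scatter, so this pair gives no sign that the acceptor is needed for the effect. Nothing measured here explains why the two groups read alike.

An amine or a carboxylic acid at this position could still read differently. Going by these compounds, whether methyl, which stands in compound 2 on a core with a single fluoro, would lower the number on the core of compound 3 also stays open.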